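Diacylhydrazide sulfonamides: cyano-to-chloro step on compound 3

The source may hold more compounds than are shown below. What is called first, only, known or untested is meant among the compounds shown, and "the series" means these compounds.

Three compounds have numbers in an assay on cells for inhibition of Amine oxidase [flavin-containing] A (Homo sapiens), read by fluorescence and spectrophotometry, using microsomes, with a stated time of 20 min; a higher number here means a weaker inhibitor, a lower number a stronger inhibitor. Compound 1 `NS(=O)(=O)c1ccc(C(=O)NNC(=O)c2ccccc2)cc1` gives 62800 nM, compound 2 `N#Cc1ccc(-c2nnc(-c3ccc(S(N)(=O)=O)cc3)o2)cc1` gives 24300 nM, and compound 3 `N#Cc1ccc(C(=O)NNC(=O)c2ccc(S(N)(=O)=O)cc2)cc1` gives 16100 nM. Among the compounds with values here, compound 3 has the lowest of the three numbers; its gap to compound 2 is within the scatter, while its gap to compound 1 is beyond it: a 3.9-fold lower number from compound 1 to compound 3 (0.59 log units; beyond the scatter), the single one-place step known in this set.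

Compound 4 `NS(=O)(=O)c1ccc(C(=O)NNC(=O)c2ccc(Cl)cc2)cc1` differs from compound 3 in one place: chloro in place of cyano on an aromatic carbon. Within the data shown here, no measured step covers chloro directly. Among the measured compounds shown here, the one step that bears on the position, from compound 1 to compound 3, shows that removing everything from that carbon costs a modest amount, so a chloro there is expected to land between the two, not far from compound 3. The estimated number for compound 4 in this assay is 25000 nM, with a range of 8000 nM to 80000 nM, which means an expected step of a 1.6-fold higher number from compound 3 to compound 4 (0.19 log units; within the scatter), within the scatter.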

Compound 4, half-maximal inhibitory concentration: 55900 nM
Compound 4: middle estimate off by 2.2-fold (0.35 log units), on the low side; low and high end bracket the measured number.
By their numbers in this assay, from the lowest: compounds 3 and 2 (each within the scatter of the next); then compounds 4 and 1 (each within the scatter of the next).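

At this aromatic carbon in this assay, chloro does not stand in for cyano: the exchange gives a 3.5-fold higher number from compound 3 to compound 4 (0.54 log units; beyond the scatter) and so gives up the gain seen with cyano. Chloro in place of hydrogen gives a 1.1-fold lower number from compound 1 to compound 4 (0.05 log units; within the scatter) and thus no separation, so among hydrogen, chloro and cyano at this carbon, only cyano stands apart, and merely filling the position is not enough for the lower number. No measurement on hand accounts for the difference between cyano and chloro at this carbon.

Going by these compounds, whether cyano is unique here remains open, and a carboxylic acid, an amine or a methoxy group on the same carbon would help to settle it. Also open, on these data alone, is whether the chloro-for-cyano step carries over to the core of compound 2, for which only the cyano member stands here.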